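The compounds below may be only part of what the source reports. "The series", "measured", "known", "first", "only" and "open" are said of these compounds alone.

In a functional assay on MCF7 cells (Homo sapiens) for inhibition, read by sulforhodamine B assay (on this read-out lower numbers stand for stronger inhibition and higher numbers for weaker inhibition), compound 1 (`Cc1ccc(NC2=CC(=O)c3c(nc4n3[C@H]3OC[C@@H](O)[C@H]3OC4)C2=O)cc1`) gives > 4000 nM, which is a limit of the assay. Compound 2 (`O=C1C(Nc2ccc(C(F)(F)F)cc2)=CC(=O)c2c1nc1n2[C@H]2OC[C@@H](O)[C@H]2OC1`) gives > 4000 nM, also a limit. Among the measured compounds shown here, the only measured step is a step that the two limits leave unreadable from compound 1 to compound 2, with trifluoromethyl in place of methyl on an aromatic carbon, so it offers no size to carry forward. Compound 3 (`O=C1C(N2CCC2)=CC(=O)c2c1nc1n2[C@H]2OC[C@@H](O)[C@H]2OC1`) has azetidin-1-yl in place of (4-methylphenyl)amino on a double-bonded ring carbon. This change is a different one from the measured step, which therefore bears on it only loosely. With compound 1 and compound 2 both at the limit of > 4000 nM in this assay, at which 2 of the 2 values shown sit, the data give no direction, and compound 3 is expected to remain near that limit. The estimated step is a step that the limit leaves unreadable from compound 1 to compound 3, with no firm direction expected. For compound 3 the estimated value is 5000 nM, with an expected range of 1500 nM to 20000 nM.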

Compound 3, half-maximal inhibitory concentration: > 16000 nM
Compound 3 ended at the assay's limit; the forecaster's own chance of this, stated with the estimate: 65%; middle value at least 3.2-fold (0.50 log units) from the limit.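

Compound 1 and compound 3 both ended at limits of the assay rather than at actual numbers, and the step between them cannot be read. The compounds shown leave open how strongly any of them inhibits these cells, and whether swapping (4-methylphenyl)amino for azetidin-1-yl changes that inhibition at all.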